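The source may hold more compounds than are shown below. What is called first, only, known or untested is meant among the compounds shown, and "the series" means these compounds.

Series notes, step from compound 1 to compound 4.

Compound 1 `COC(=O)/C=C/c1cccc(N(Cc2ccc(/C=C/c3c(C)cc(C)cc3C)cc2)C(=O)C(C)C)c1` is the reference. In an assay on isolated protein with Bile acid receptor (Homo sapiens) as the target (on this read-out lower numbers stand for an effect already at smaller amounts and higher numbers for an effect only at larger amounts of compound), compound 1 gives 149 nM, the lowest of the two numbers at hand. Compound 2 `COC(=O)/C=C/c1cccc(N(Cc2ccc(/C=C/c3c(C)cc(C)cc3C)cc2)C(=O)NC(C)C)c1` gives 431 nM in this assay. Going by the values given here, the one measured step, a 2.9-fold higher number from compound 1 to compound 2 (0.46 log units; beyond the scatter), concerns isopropylamino in place of isopropyl on a carbonyl carbon. Compound 3 `CCOC(=O)/C=C/c1ccc(CN(C(=O)C2CCCCC2)c2cccc(/C=C/C(=O)OC)c2)cc1` gives only a limit of this assay, > 1000 nM; this is the limit of > 1000 nM in this assay, at which 1 of the 3 values shown sits.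

Compound 4 `COC(=O)/C=C/c1cccc(N(Cc2ccc(-c3ccc(F)c(Cl)c3)cc2)C(=O)C(C)C)c1` differs from compound 1 by 3-chloro-4-fluorophenyl in place of 2-(2,4,6-trimethylphenyl)ethenyl on an aromatic carbon. Among the compounds with values here, no measured step touches this part of the molecule: the step from compound 1 to compound 2 sits at the carbonyl carbon, and compound 3 differs from compound 1 in two places at once and reports only a limit. Within the data shown here, the change therefore rests on no measured precedent, and a step beyond the scatter in either direction cannot be ruled out. Compound 4 is expected at about 600 nM in this assay, between 150 nM and 3000 nM, which would mean an estimated step of a 4.0-fold higher number from compound 1 to compound 4 (0.60 log units; beyond the scatter).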

Compound 4, half-maximal effective concentration: 129 nM
Estimate against measurement, compound 4: 4.7-fold (0.67 log units) above; measured number below the stated range.
By their numbers in this assay, from the lowest: compounds 4 and 1 (each within the scatter of the next); then compound 2. At a limit, above all of these: compound 3.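

A reading of a 1.2-fold lower number from compound 1 to compound 4 (0.06 log units; within the scatter) in this assay shows that, on the aromatic carbon para to a large group, 3-chloro-4-fluorophenyl can replace 2-(2,4,6-trimethylphenyl)ethenyl with no difference beyond the scatter. Going by these compounds alone, this is the first measured change at this position, and the read-out holds even though the entering group has fewer heavy atoms than the leaving group and lacks the double bond outside aromatic rings. Nothing at hand explains why the two groups read alike.

Open, going by these compounds, is how an amine or a carboxylic acid at this position would read, and whether the chlorine and the fluorine each matter, as only the complete 3-chloro-4-fluorophenyl group appears here. Also open, on these data alone, is whether isopropylamino on the carbonyl carbon would give the same step with this group in place.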